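Series notes: aryl change from compound 2 to compound 3

This account rests on a few compounds, and the source may have more. Where it says the series, first, only, none or still open, it means among the compounds named here.

Measured in a functional assay on the whole organism (strain CD-1) for inhibition, with Mus musculus as the target, in the writhing test, with stated times of 15 min and 20 min, at a dose of 10 mg/kg by the subcutaneous route; on this read-out lower numbers stand for less inhibition and higher numbers for more inhibition at the one dose given (going by the name of the read-out):
compound 1 `N#C/C(=C\c1ccccc1)C(=O)OC/C=C/c1ccccc1`: 25.1%
compound 2 `Cc1ccc(/C=C(\C#N)C(=O)OC/C=C/c2ccccc2)cc1C`: 18.4%

Among the measured compounds shown here, compound 2 holds the lower of the two numbers, yet the only step, a number 6.7 percentage points lower from compound 1 to compound 2 (within the scatter), is within the scatter, so no order between compound 1 and compound 2 can be claimed.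

Compound 3 `N#C/C(=C\c1ccc(Cl)c(Cl)c1)C(=O)OC/C=C/c1ccccc1` differs from compound 2 in one place: 3,4-dichlorophenyl in place of 3,4-dimethylphenyl on a double-bonded chain carbon bound to a double-bonded chain carbon. For the measured compounds named here, no measured step bears directly on exchanging 3,4-dichlorophenyl for 3,4-dimethylphenyl. Going by the values given here, the one step known, phenyl to 3,4-dimethylphenyl on a double-bonded chain carbon bound to a double-bonded chain carbon, was small and within the scatter. With nothing pointing to a shift, compound 3 is expected to stay close to compound 2, with an estimated step of a number 2.6 percentage points higher from compound 2 to compound 3 (within the scatter), none beyond the scatter. In this assay compound 3 is therefore estimated at 21%, with a range from 6% to 38%.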

Compound 3, a percentage reported as inhibition, in the whole organism at one dose (the size of the read-out at that dose, not a potency): 30.7%
Estimate against measurement, compound 3: 9.7 percentage points below, and the stated range covers the measured number.
By their numbers in this assay, from the lowest: compounds 2, 1 and 3 (each within the scatter of the next, the first and the last beyond it).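

At the aryl group on a double-bonded chain carbon bound to a double-bonded chain carbon, this assay now separates two substituted rings: 3,4-dichlorophenyl in place of 3,4-dimethylphenyl gives a number 12.3 percentage points higher from compound 2 to compound 3 (beyond the scatter). The two groups have the same count of heavy atoms and the same ring, so the exchange of the two methyl carbons for two chlorines goes with a modest difference at this position. Against the unsubstituted phenyl, the same 3,4-dichlorophenyl gives a number 5.6 percentage points higher from compound 1 to compound 3 (within the scatter), so only the two substituted rings stand apart, and no evidence on hand accounts for that difference.

Open, on these data alone, is how a single chlorine, an amine or a carboxylic acid on this ring would read in this assay. Also open, as far as these compounds go, is whether the separation between 3,4-dichlorophenyl and 3,4-dimethylphenyl would hold with a longer chain in the rest of the core.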